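Swapping the pyridine for a phenyl on the benzylpiperazine

The source may report more compounds than this note shows. Statements on the series, on what has been measured and on what is new or still open speak of the compounds shown alone.

Of the compounds shown here, three sharing one core have been measured in a functional assay on MGC-803 cells (Homo sapiens) for antiproliferative activity, read by CCK-8 assay, with a stated time of 72 h, tested at 2 uM; on this read-out higher numbers stand for a stronger effect at the one concentration tested and lower numbers for a weaker effect. Compound 1 `Nc1ccccc1NC(=O)c1ccc(CSC(=S)N2CCN(Cc3ccncc3)CC2)cc1` gives 18.4%, compound 2 `Nc1ccccc1NC(=O)c1ccc(CSC(=S)N2CCN(c3ncccn3)CC2)cc1` gives 28.4%, and compound 3 `Nc1ccccc1NC(=O)c1ccc(CSC(=S)N2CCN(Cc3cccnc3)CC2)cc1` gives 37.7%, the highest of the three numbers, though its gap to compound 2 is within the scatter. The next compound, compound 4 `Nc1ccccc1NC(=O)c1ccc(CSC(=S)N2CCN(Cc3ccccc3)CC2)cc1`, differs from compound 3 by phenyl in place of pyridin-3-yl on a saturated chain carbon bound to an amine nitrogen in a ring. Among the compounds with values here, no measured step involves a phenyl at this place, so only the neighbouring steps bear on it: a number 19.3 percentage points higher from compound 1 to compound 3 (beyond the scatter) and a number 9.3 percentage points higher from compound 2 to compound 3 (within the scatter). Since changes of the aryl group at this position gave at most modest steps, compound 4 is expected to lie within the scatter of compound 3, at an estimated 30% with a range from 15% to 45%, an expected step of a number 7.7 percentage points lower from compound 3 to compound 4 (within the scatter).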

Compound 4, a percentage reported as inhibition, at one concentration (the size of the read-out at that concentration, not a potency): 18.1%
Compound 4: the middle estimate sits 11.9 percentage points above what was measured; the range from low to high includes it.
By their numbers in this assay, from the lowest: compounds 4, 1, 2 and 3 (each within the scatter of the next, the first and the last beyond it).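

In this assay the pyridin-3-yl proves not to be interchangeable with phenyl at this place, with a number 19.6 percentage points lower from compound 3 to compound 4 (beyond the scatter) and thus a step as large as the one that separated the two pyridines. Phenyl gives no such step against pyridin-4-yl, with a number 0.3 percentage points lower from compound 1 to compound 4 (within the scatter) so only the pyridin-3-yl stands apart from phenyl, while benzyl also falls short of pyrimidin-2-yl, with a number 10.3 percentage points lower from compound 2 to compound 4 (beyond the scatter) as the step. Nothing available explains these differences. Left open is whether pyridin-2-yl would match pyridin-3-yl, and whether an amine or a methoxy group on the phenyl would change the number.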